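Chloro versus Dimethylamino in Two Matched Pairs

A few compounds are considered here, and "the series" means these few. Any claim that something is new, unique, unknown or untested is made for them only; others in the source may bear on it.

Measured compounds:
compound 1 `Clc1[nH]ccc2ncnc1-2`: in a functional assay (Homo sapiens) for inhibition of Nucleic Acid, tested at 100 uM (a higher number here means more inhibition at the concentration tested (going by the name of the read-out), a lower number less inhibition), compound 1 gives 6%
compound 2 `OC[C@H]1OC(n2cnc3c(Cl)nccc32)[C@H](O)[C@@H]1O`: in this assay compound 2 gives 76%
compound 3 `CN(C)c1[nH]ccc2ncnc1-2`: in this assay compound 3 gives 8%

Compound 1 and compound 3 share a core and differ in one place, (dimethylamino in place of chloro on an aromatic carbon). The step in this assay is a number 2 percentage points higher from compound 1 to compound 3 (within the scatter), so the two values cannot be told apart. Compound 2 carries a different core; how it differs from compound 1 is not broken down here. Compound 2 stands apart from both smaller compounds in this assay, with compound 3 the nearer and compound 1 the further of the two.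

Compound 4 `CN(C)c1nccc2c1ncn2C1O[C@H](CO)[C@@H](O)[C@H]1O` is not yet measured. It relates to compound 2 as compound 3 relates to compound 1: the change is dimethylamino in place of chloro on an aromatic carbon, the same change at the same kind of place. Because the earlier step was a number 2 percentage points higher from compound 1 to compound 3 (within the scatter), a similarly small step in this assay is expected here, giving an estimated a number 6 percentage points lower from compound 2 to compound 4 (within the scatter) for compound 4. The estimate for compound 4 in this assay is 70%, expected to fall between 45% and 90%; it rests on one pair only.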

Compound 4, a percentage reported as inhibition, at one concentration (the size of the read-out at that concentration, not a potency): 0%
Estimate against measurement, compound 4: 70 percentage points above; measured number below the stated range.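

The change from chloro to dimethylamino does not carry from one core to the other in this assay: the same change on two cores in this assay, a number 2 percentage points higher (within the scatter) from compound 1 to compound 3 and a number 76 percentage points lower (beyond the scatter) from compound 2 to compound 4, 78 percentage points apart, beyond the scatter of two such steps.
On the core of compound 2 the change reads a number 76 percentage points lower from compound 2 to compound 4 (beyond the scatter) and takes the number down from a high value to none, so the small step on the core of compound 1 gave no guide to this core. Within the data shown here, this does not show why the two cores differ, and with only two pairs it sets no rule for the change in general; compound 1 at 6% also stands so low that little room for a fall exists on that core.

The compounds shown leave open whether the loss on the core of compound 2 is tied to dimethylamino itself or to the departure of chloro. A primary amine, methylamino, methoxy or a cyclic amine such as morpholine at the same aromatic carbon would help separate these two readings.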